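A few compounds are considered here, and "the series" means these few. Any claim that something is new, unique, unknown or untested is made for them only; others in the source may bear on it.

Measured compounds in a functional assay on SR cells (Homo sapiens) for inhibition, read by sulforhodamine B assay, with a stated time of 48 h, tested at 10 uM; on this read-out lower numbers stand for less inhibition and higher numbers for more inhibition at the one concentration tested (going by the name of the read-out):
compound 1, `O=Cc1ccc(-c2cn3ccnc3c(-c3ccc4ncn(C5CCCCC5)c4c3)n2)cc1`, gives 47.5%
compound 2, `c1ccc2c(-c3cn4ccnc4c(-c4ccc5ncn(C6CCCCC6)c5c4)n3)cccc2c1`, gives 6.92%
compound 3, `c1cn2cc(-c3ccsc3)nc(-c3ccc4ncn(C5CCCCC5)c4c3)c2n1`, gives 14.3%

Compound 1 stands highest of the three numbers in this assay. Its nearest neighbour is compound 3, reached by a number 33.2 percentage points lower from compound 1 to compound 3 (beyond the scatter), and the furthest is compound 2, reached by a number 40.6 percentage points lower from compound 1 to compound 2 (beyond the scatter). Between compound 2 and compound 3 the step is a number 7.4 percentage points higher from compound 2 to compound 3 (within the scatter).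

Compound 4, `Clc1ccc(-c2cn3ccnc3c(-c3ccc4ncn(C5CCCCC5)c4c3)n2)cc1`, differs from compound 1 in one place: chloro in place of formyl on an aromatic carbon. For the measured compounds named here, no measured step exchanges one group on the phenyl ring for another; the two measured steps from compound 1 each replace the whole 4-formylphenyl by a different ring system and both are large and downward. They bear on the present step only loosely, since compound 4 keeps the phenyl ring. A moderate downward step is therefore expected in this assay, smaller than either measured step, though a number within the scatter of compound 1 cannot be ruled out. Compound 4 is estimated at 30%, with a range from 5% to 55%. The expected step is a number 17.5 percentage points lower from compound 1 to compound 4 (beyond the scatter).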

Compound 4, a percentage reported as inhibition, at one concentration (the size of the read-out at that concentration, not a potency): 18.5%
Beside the measured number, compound 4's estimate is 11.5 percentage points above it; the range from low to high includes it.
By their numbers in this assay, from the lowest: compounds 2, 3 and 4 (each within the scatter of the next, the first and the last beyond it); then compound 1.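

In this assay, keeping the phenyl ring does not by itself hold the number up: on the carbon para to a large group, the exchange of formyl for chloro gives a number 29 percentage points lower from compound 1 to compound 4 (beyond the scatter) and so takes away most of what set compound 1 apart. With chloro in place, the 4-chlorophenyl group gives a number 4.2 percentage points higher from compound 3 to compound 4 (within the scatter) against thiophen-3-yl, and a number 11.6 percentage points higher from compound 2 to compound 4 (beyond the scatter) against naphthalen-1-yl, so among these compounds only the 4-formylphenyl group stands clear of the others. Nothing at hand explains what the formyl group contributes.

On these data alone, it remains open whether a carboxylic acid, an acetyl group or an aminomethyl group at this place would give a number like that of compound 1. Also open, as far as these compounds go, is whether the formyl group would do the same on another carbon of the phenyl ring.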